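Heteroaryl ether variation at the shared acid core

The compounds below may be only part of what the source reports. "The series", "measured", "known", "first", "only" and "open" are said of these compounds alone.

compound 1 `CC(C)(C)Sc1c(CC(C)(C)C(=O)O)n(Cc2ccc(Cl)cc2)c2ccc(OCc3cc4ccccc4cn3)cc12` — 3 nM
compound 2 `C[C@@H](COc1ccc2c(c1)c(SC(C)(C)C)c(CC(C)(C)C(=O)O)n2Cc1ccc(Cl)cc1)c1ccccn1` — 2 nM
compound 3 `C[C@H](COc1ccc2c(c1)c(SC(C)(C)C)c(CC(C)(C)C(=O)O)n2Cc1ccc(Cl)cc1)c1ccccn1` — 3 nM

In a functional assay for inhibition, with Homo sapiens as the target (a lower number here means a stronger inhibitor, a higher number a weaker inhibitor), compound 1 stands level with compound 3 at the digits printed, the two together giving the highest of the three numbers; the nearest is compound 3 (no change at the digits printed from compound 1 to compound 3 (within the scatter)), the furthest compound 2 (a 1.5-fold lower number from compound 1 to compound 2 (0.18 log units; within the scatter)). Compound 4 `CC(C)c1csc(COc2ccc3c(c2)c(SC(C)(C)C)c(CC(C)(C)C(=O)O)n3Cc2ccc(Cl)cc2)n1` differs from compound 1 in one place: 4-isopropyl-1,3-thiazol-2-yl in place of isoquinolin-3-yl on a saturated chain carbon bound to an oxygen on an aromatic ring. The steps already measured at this same position, from compound 1 to compound 2 and from compound 1 to compound 3, both lie within the scatter, as does the step between the two configurations (a 1.5-fold higher number from compound 2 to compound 3 (0.18 log units; within the scatter)), which rests on (the fact that compounds 2 and 3 differ only in the configuration as drawn). For compound 4 no change beyond the scatter is therefore expected (no change at the digits printed from compound 1 to compound 4 (within the scatter)). Compound 4 is estimated at 3 nM, with a range from 1 nM to 10 nM.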

Compound 4, half-maximal inhibitory concentration: 3 nM
Beside the measured number, compound 4's estimate shows no gap at the digits printed, and the stated range covers the measured number.
By their numbers in this assay, from the lowest: compounds 2, 1, 3 and 4 (each within the scatter of the next).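

Placing 4-isopropyl-1,3-thiazol-2-yl gives no change at the digits printed from compound 1 to compound 4 (within the scatter) in this assay, with no change at the digits printed from compound 3 to compound 4 (within the scatter) and a 1.5-fold higher number from compound 2 to compound 4 (0.18 log units; within the scatter) against 1-(pyridin-2-yl)ethyl. The place on a saturated chain carbon bound to an oxygen on an aromatic ring thus also accepts a five-membered aromatic ring with 2 hetero atoms, not only the groups seen earlier. Nothing measured here speaks to why the number holds.

On these data alone, whether a primary amine or a carboxylic acid at this place keeps the number stays open. So does whether any group here gives a step beyond the scatter.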